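Removing Fluorine from the Hydrazone Aryl Ring

The source may report more compounds than this note shows. Statements on the series, on what has been measured and on what is new or still open speak of the compounds shown alone.

Three compounds sharing one core were tested in a functional assay on A549 cells (Homo sapiens) for cytotoxicity, read by MTT assay, with a stated time of 72 h; a lower number here means a stronger inhibitor, a higher number a weaker inhibitor. Compound 1 `CN(C)CCn1cnnc1-c1cc(Oc2ccc(NC(=O)N/N=C/c3c(Cl)cccc3Cl)cc2F)ccn1` carries 2,6-dichlorophenyl on the carbon double-bonded to nitrogen and gives 1410 nM. Compound 2 `CN(C)CCn1cnnc1-c1cc(Oc2ccc(NC(=O)N/N=C/c3ccc(O)cc3)cc2F)ccn1` carries 4-hydroxyphenyl there and gives 3560 nM. Compound 3 `CN(C)CCn1cnnc1-c1cc(Oc2ccc(NC(=O)N/N=C/c3ccc(O)c(F)c3)cc2F)ccn1` carries 3-fluoro-4-hydroxyphenyl and gives 13400 nM, the highest of the three numbers, so it is the weakest inhibitor in this set. The steps are a 2.5-fold higher number from compound 1 to compound 2 (0.40 log units; beyond the scatter), a 9.5-fold higher number from compound 1 to compound 3 (0.98 log units; beyond the scatter) and a 3.8-fold higher number from compound 2 to compound 3 (0.58 log units; beyond the scatter).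

Compound 4 `CN(C)CCn1cnnc1-c1cc(Oc2ccc(NC(=O)N/N=C/c3cccc(O)c3)cc2F)ccn1` has not yet been measured. It differs from compound 3 in one place: 3-hydroxyphenyl in place of 3-fluoro-4-hydroxyphenyl on a carbon with a double bond to nitrogen. Two things change at once: the fluorine leaves, and the hydroxyl is 3-hydroxyphenyl rather than 4-hydroxyphenyl. Only the first change has a measured counterpart, the step of a 3.8-fold higher number from compound 2 to compound 3 (0.58 log units; beyond the scatter), which ran the opposite way when fluorine was added. For the measured compounds named here, no measured pair shows 3-hydroxyphenyl against 4-hydroxyphenyl, so that part is uncertain. The estimated step is therefore a 3.0-fold lower number from compound 3 to compound 4 (0.47 log units; beyond the scatter), toward a lower number, because removal of fluorine reverses a 3.8-fold higher number from compound 2 to compound 3 (0.58 log units; beyond the scatter). Compound 4 is expected to give about 4500 nM in this assay , within a range from 1500 nM to 13000 nM.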

Compound 4, half-maximal inhibitory concentration: > 100000 nM
Compound 4 was reported as a limit (the forecaster's own chance of this, stated with the estimate: 5%); at least 22-fold (1.34 log units) between middle value and limit.
By their numbers in this assay, from the lowest: compound 1; then compound 2; then compound 3. At a limit, above all of these: compound 4.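

For the compounds shown here, the place of the hydroxyl on this aryl ring, which sits on the carbon with a double bond to nitrogen, proves to matter far more than the earlier compounds could show: 3-hydroxyphenyl in place of 4-hydroxyphenyl gives an at least 28-fold higher number from compound 2 to compound 4 (1.44 log units; beyond the scatter), a larger step than any seen among the first three compounds. Compound 4 also has no fluorine on this ring, yet it does not regain the ground lost with the fluorine, with an at least 7.4-fold higher number from compound 3 to compound 4 (0.87 log units; beyond the scatter), and the distance from the dichlorinated compound is an at least 70-fold higher number from compound 1 to compound 4 (1.85 log units; beyond the scatter). Compound 4 is reported only as a limit and not as a number, so each of these steps is a minimum: the limit of > 100000 nM in this assay, at which 1 of the 4 values shown sits.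

Going by these compounds, how far compound 4 lies beyond that limit stays open, and so does whether adding fluorine to 3-hydroxyphenyl would change anything, since the fluorine has been seen only alongside a hydroxyl in the 3-fluoro-4-hydroxyphenyl group. On these data alone, it is also open whether the hydroxyl itself is needed, which a methoxy group or an amine in its place on the 4-hydroxyphenyl ring would test.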